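Working notes: compound 4 and the hydroxyl-bearing substituent

The compounds below may be only part of what the source reports. "The series", "measured", "known", "first", "only" and "open" are said of these compounds alone.

Measured so far in a functional assay on CHO cells for antagonist activity at C-C chemokine receptor type 4 (Homo sapiens), read by GTPgammaS binding; a lower number here means a stronger inhibitor, a higher number a weaker inhibitor:
compound 1 `CC(=O)NCc1cccc(Cn2nc(NS(=O)(=O)c3ccc(Cl)s3)c3ccccc32)c1`: 251 nM
compound 2 `CC(=O)NCc1cccc(Cn2nc(NS(=O)(=O)c3ccc(Cl)s3)c3c(Cl)cccc32)c1`: 31.6 nM
compound 3 `CC(=O)NCc1cccc(Cn2nc(NS(=O)(=O)c3ccc(Cl)s3)c3c(CO)cccc32)c1`: 6.31 nM

Compound 3 gives the lowest number of the three. Its nearest neighbour is compound 2, with a 5.0-fold lower number from compound 2 to compound 3 (0.70 log units; beyond the scatter); compound 1 is furthest, with a 40-fold lower number from compound 1 to compound 3 (1.60 log units; beyond the scatter). The step from the unsubstituted core to the chlorinated one, a 7.9-fold lower number from compound 1 to compound 2 (0.90 log units; beyond the scatter), is the smallest of the three shown.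

Compound 4 `CC(=O)NCc1cccc(Cn2nc(NS(=O)(=O)c3ccc(Cl)s3)c3c(C(C)(C)O)cccc32)c1` differs from compound 3 in one place: 1-hydroxy-1-methylethyl in place of hydroxymethyl on an aromatic carbon. The count of hydrogen-bond donors and acceptors is unchanged; two carbons are added on the carbon that carries the hydroxyl.

Within the data shown here, no measured step in this assay exchanges one hydroxyl-bearing group for another, so none bears directly on the change. The steps that exist replace hydrogen or chloro with hydroxymethyl and are modest to large in the lowering direction; they say only that the hydroxyl-bearing substituent sits at the low end of the numbers seen. The present change keeps that group and enlarges it, and the expectation is a step in this assay within or near the scatter, in either direction, a 1.6-fold higher number from compound 3 to compound 4 (0.20 log units; within the scatter). Compound 4 is accordingly estimated at 10 nM in this assay, with a range from 2.5 nM to 40 nM.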

Compound 4, half-maximal inhibitory concentration: 100 nM
Estimate against measurement, compound 4: 10-fold (1.00 log units) below, and the stated range ends below it.
By their numbers in this assay, from the lowest: compound 3; then compound 2; then compound 4; then compound 1.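

In this assay the hydroxyl-bearing groups at this aromatic carbon prove not to be interchangeable: 1-hydroxy-1-methylethyl in place of hydroxymethyl gives a 16-fold higher number from compound 3 to compound 4 (1.20 log units; beyond the scatter) with the counts of hydrogen-bond donors and acceptors unchanged, so the low number seen with hydroxymethyl does not carry over to the larger group. Against hydrogen the larger group keeps only part of the gain, with a 2.5-fold lower number from compound 1 to compound 4 (0.40 log units; beyond the scatter) and it also falls behind chloro, with a 3.2-fold higher number from compound 2 to compound 4 (0.50 log units; beyond the scatter) so the presence of a hydroxyl-bearing substituent at this position does not by itself secure a low number. No measurement available here bears on the reason for this step.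

The compounds shown leave open whether the rise follows from the added carbons as such or from the carbon carrying the hydroxyl having two methyl groups, a question that 1-hydroxyethyl, with a single methyl, would help to separate. Also open, going by these compounds, is how a longer chain such as 2-hydroxyethyl, an amine such as aminomethyl, or a carboxylic acid on the same aromatic carbon would compare with hydroxymethyl in this assay.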